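Formyl to Ethyl Ester in a Weakly Cytotoxic Series

The source may hold more compounds than are shown below. What is called first, only, known or untested is meant among the compounds shown, and "the series" means these compounds.

Three compounds have so far been run in a functional assay on A549 cells (Homo sapiens) for cytotoxicity, read by MTT assay; on this read-out higher numbers stand for weaker inhibition and lower numbers for stronger inhibition. Compound 1 `CCOC(=O)c1oc2c(Br)c(OC)cc(OC)c2c1C` reaches only a limit of the assay, > 87400 nM. Compound 2 `COc1cc(OC)c2c(C)c(C(=O)NCc3ccccc3)oc2c1C(N)=O` gives 54800 nM. Compound 3 `Cc1c(C=O)oc2c(C(N)=O)c(O)cc(O)c12` gives 108000 nM, the higher of the two real numbers, though compound 2 lies within the usual scatter of it. One of the three values sits at the limit of > 87400 nM in this assay, at which 1 of the 3 values shown sits.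

Compound 4 `CCOC(=O)c1oc2c(C(N)=O)c(O)cc(O)c2c1C` differs from compound 3 by ethoxy in place of hydrogen on a carbonyl carbon. Within the data shown here, no pair of measured compounds shows this change alone, so its effect is untested here; the change is small and all values so far are weak. Compound 4 is expected to stay weak, with a step of a 1.1-fold lower number from compound 3 to compound 4 (0.03 log units; within the scatter) expected to be no larger than the scatter. Compound 4 is estimated at 100000 nM, within a range from 40000 nM to 250000 nM.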

Compound 4, half-maximal inhibitory concentration: 24000 nM
Beside the measured number, compound 4's estimate is 4.2-fold (0.62 log units) above it; the whole stated range lies above it.
By their numbers in this assay, from the lowest: compound 4; then compounds 2 and 3 (each within the scatter of the next).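

On a carbonyl carbon whose other neighbour is an aromatic carbon, ethoxy in place of hydrogen gives a 4.5-fold lower number from compound 3 to compound 4 (0.65 log units; beyond the scatter) in this assay. Among these compounds, this is the first single change that can be read here. The earlier compounds shown here differ in more than one place. The step shows that this position can move the number by a modest amount. Among the compounds shown here, nothing measured so far accounts for the step.

As far as these compounds go, whether a carboxylic acid, an amide or a longer ester chain at this carbon would lower the number further remains open. So does whether formyl to ethoxycarbonyl has a similar effect with other groups on the shared core.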